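Hydroxyphenyl for dimethoxyphenyl: expected growth inhibition of compound 4

The source may hold more compounds than are shown below. What is called first, only, known or untested is meant among the compounds shown, and "the series" means these compounds.

Three compounds built on the shared core carry measurements in a functional assay on K562 cells (Homo sapiens) for inhibition, read by fluorescence, with a stated time of 72 h; a lower number here means a stronger inhibitor of growth, a higher number a weaker inhibitor of growth. Compound 1 `COc1ccc(Nc2nc(N[C@H]3CC[C@H](N)CC3)nc3c2ncn3CCC(C)C)c(OC)c1` gives 5500 nM in this assay. Compound 2 `CCCCCCn1cnc2c(Nc3cc(OC)cc(OC)c3)nc(N[C@H]3CC[C@H](N)CC3)nc21` gives 1900 nM, and compound 3 `N[C@H]1CC[C@H](Nc2nc(Nc3cccc(Cl)c3)c3ncn(Cc4ccccc4)c3n2)CC1` gives 3000 nM. Compound 1 therefore holds the highest of the three numbers; against compound 3 the gap lies within the usual scatter, so no order between those two can be read, whereas compound 2 sits beyond the scatter with the lower number. The three measured compounds differ from one another in more than one place, so none of these gaps can be tied to a single structural change.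

Compound 4 `CC(C)CCn1cnc2c(Nc3ccc(O)cc3)nc(N[C@H]3CC[C@H](N)CC3)nc21` is not yet measured. It differs from compound 1 in one place: 4-hydroxyphenyl in place of 2,4-dimethoxyphenyl on a nitrogen on an aromatic ring. No measured pair in the series isolates this change, and no measured pair isolates any change at that nitrogen, so the direction of the step rests on no shown step. The working expectation is a step of a 1.2-fold lower number from compound 1 to compound 4 (0.09 log units; within the scatter), meaning no shift beyond the scatter, with either direction possible. Compound 4 is accordingly estimated at 4500 nM in this assay, with a range from 1500 nM to 14000 nM.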

Compound 4, concentration for 50% growth inhibition: 4600 nM
For compound 4 the middle estimate is 1.0-fold (0.01 log units) below the measured one, within the range that was stated.
By their numbers in this assay, from the lowest: compounds 2, 3, 4 and 1 (each within the scatter of the next, the first and the last beyond it).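

In this assay, among the compounds shown here, the first step that isolates a single place gives a 1.2-fold lower number from compound 1 to compound 4 (0.08 log units; within the scatter), with 4-hydroxyphenyl in place of 2,4-dimethoxyphenyl on a nitrogen on an aromatic ring. This position therefore tolerates a swap that removes both methoxy groups, adds a hydroxyl and brings in a hydrogen-bond donor where the leaving group has none, with no shift in growth inhibition that can be told from the scatter. Nothing available here accounts for this outcome, and the step alone cannot separate the contributions of the individual groups on the ring.

Still open, going by these compounds, is whether any group on this ring moves the number beyond the scatter, for instance an amine or a carboxylic acid in place of the hydroxyl, or a single methoxy group as the only substituent. Also open, on these data alone, is whether the same swap gives a step of similar size when the other substituents on the shared core are different, since this single pair rests on the core of compound 1 alone.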